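The source may report more compounds than this note shows. Statements on the series, on what has been measured and on what is new or still open speak of the compounds shown alone.

Measured so far in a functional assay on HCT-116 cells (Homo sapiens) for inhibition, read by MTT assay, with a stated time of 48 h; on this read-out higher numbers stand for weaker inhibition and lower numbers for stronger inhibition:
compound 1 `CCCCC(=O)N(Cc1ccc(OC)c(O)c1)c1cc(OC)c(OC)c(OC)c1` gives 170 nM
compound 2 `C/C=C/C(=O)N(Cc1ccc(OC)c(OC)c1)c1cc(OC)c(OC)c(OC)c1` gives 32800 nM
compound 3 `COC(=O)c1cc(CNc2cc(OC)c(OC)c(OC)c2)ccc1OC` gives 38100 nM

Compound 1 has the lowest number of the three in this assay and therefore the strongest inhibition, with compound 2 and compound 3 both far higher and beyond the scatter. The next compound to be read is compound 4 `CC/C=C/C(=O)N(Cc1ccc(OC)c(O)c1)c1cc(OC)c(OC)c(OC)c1` which has not been measured. It keeps the core of compound 1 and alters only the chain (but-1-en-1-yl in place of butyl on a carbonyl carbon) by placing but-1-en-1-yl in place of butyl on a carbonyl carbon.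

Going by the values given here, no measured pair isolates this change, so the expectation has no direct support. Compound 2 also has a double bond in its chain and reads 32800 nM in this series, but it differs from compound 1 in more than the chain, and that gap cannot be assigned to the double bond. It does leave some room for a larger loss, so the upper end of the range is set wide. Expected in this assay is a 1.8-fold higher number from compound 1 to compound 4 (0.25 log units; within the scatter) as a small move toward weaker inhibition, within the scatter. For compound 4 the estimate is 300 nM with an expected range from 70 nM to 2000 nM in this read-out.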

Compound 4, half-maximal inhibitory concentration: 63 nM
For compound 4 the middle estimate is 4.8-fold (0.68 log units) above the measured one; measured number outside the range, below it.
By their numbers in this assay, from the lowest: compound 4; then compound 1; then compounds 2 and 3 (each within the scatter of the next).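

In this assay, going by these compounds alone, but-1-en-1-yl in place of butyl on a carbonyl carbon gives a 2.7-fold lower number from compound 1 to compound 4 (0.43 log units; beyond the scatter), a modest move toward stronger inhibition and the first step that isolates this chain. The earlier compounds offered no pair differing in one place, so this position is now shown to respond to the chain itself: the heavy-atom count stays the same, and the change adds one double bond outside aromatic rings while the core of compound 1 stays intact. The data offer no measured basis for explaining this gain.

From the compounds shown here alone, it remains open whether the gain carries over to a shorter or longer chain, to the other geometry of the double bond, or to a triple bond or a phenyl ring at the same place. It is also open whether the step keeps its size when the hydroxyl on the core is replaced by methoxy, since no pair shown isolates that exchange.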